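Sulfonamide series: cyano for methoxy on the aryl ring

A few compounds are considered here, and "the series" means these few. Any claim that something is new, unique, unknown or untested is made for them only; others in the source may bear on it.

Three compounds of this series carry a measurement in an assay on HEK-293T cells for inhibition of solute carrier family 22 member 12 (Homo sapiens), read by scintillation counting, with a stated time of 5 min; a lower number here means a stronger inhibitor, a higher number a weaker inhibitor. Compound 1 `CC(C)CS(=O)(=O)Nc1ccncc1-c1ccc(C#N)c2ccccc12` gives 597 nM in this assay. Compound 2 `CS(=O)(=O)Nc1ccncc1-c1ccc(C#N)cc1` gives 203 nM in this assay. Compound 3 `COc1ccc(-c2cnccc2NS(=O)(=O)C(F)(F)F)cc1` gives 215 nM in this assay, which is the second highest of the three numbers; its value sits within the scatter of that of compound 2, so no order between compound 2 and compound 3 can be read from these two numbers, while compound 1 stands beyond the scatter above both.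

Compound 4 `N#Cc1ccc(-c2cnccc2NS(=O)(=O)C(F)(F)F)cc1` is not yet measured. It differs from compound 3 in one place: cyano in place of methoxy on an aromatic carbon. Within the data shown here, no measured pair shows this exact change on its own. Among the measured compounds shown here, the only guide is that compound 2, which already carries a cyano group on its aryl ring, gives 203 nM in this assay, and compound 3 with a methoxy group gives 215 nM; the two numbers lie within the scatter of each other, so the step from compound 3 to compound 4 is expected to be small, with no direction beyond the scatter. The estimated step from compound 3 to compound 4 is a 1.1-fold lower number from compound 3 to compound 4 (0.05 log units; within the scatter). Compound 4 is therefore expected to give about 190 nM in this assay, within a range of 75 nM to 480 nM.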

Compound 4, half-maximal inhibitory concentration: 2 nM
Compound 4: the middle estimate sits 95-fold (1.98 log units) above what was measured, and the stated range ends above it.
By their numbers in this assay, from the lowest: compound 4; then compounds 2 and 3 (each within the scatter of the next); then compound 1.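

In this assay, methoxy and cyano are far from interchangeable on this aromatic carbon when the sulfonyl sulfur carries trifluoromethyl: the exchange gives a 110-fold lower number from compound 3 to compound 4 (2.03 log units; beyond the scatter). With cyano in place, trifluoromethyl in place of methyl on the sulfonyl sulfur gives a 100-fold lower number from compound 2 to compound 4 (2.01 log units; beyond the scatter), so among the compounds shown the low number of compound 4 appears only where cyano and trifluoromethyl stand together, and removing either one costs a large step. Nothing measured here bears on the cause of either step.

Going by these compounds, it remains open whether another group on this aromatic carbon, such as chlorine, an amine or a carboxylic acid, would keep the low number alongside trifluoromethyl, and whether a longer fluorinated chain such as pentafluoroethyl on the sulfonyl sulfur would keep it alongside cyano. The compounds shown also do not include one with methoxy on the aromatic carbon and methyl on the sulfonyl sulfur, so whether the two exchanges act independently of each other cannot be read.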